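Swapping an aryl amide for cyclopentyl on the shared core

The source may report more compounds than this note shows. Statements on the series, on what has been measured and on what is new or still open speak of the compounds shown alone.

Of the compounds shown here, two built on the same core have been measured in a functional assay on cells for positive allosteric modulation of metabotropic glutamate receptor 5 (Rattus norvegicus), read by calcium flux; a lower number here means that less compound is needed, a higher number that more compound is needed for the effect. Compound 1 `O=C(Nc1cc(-c2ccccc2)nn1-c1ccccc1)c1cccc(C(F)(F)F)c1` gives 228 nM, and compound 2 `N#Cc1cccc(C(=O)Nc2cc(-c3ccccc3)nn2-c2ccccc2Br)c1` gives 50 nM. Of these two numbers, compound 1 holds the higher one, so more of it is needed than of compound 2, and the gap between them lies beyond the scatter.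

Compound 3 `O=C(Nc1cc(-c2ccccc2)nn1-c1ccccc1)C1CCCC1` has not yet been measured in this assay. It differs from compound 1 at a single spot: cyclopentyl in place of 3-(trifluoromethyl)phenyl on a carbonyl carbon. Going by the values given here, no measured pair here shows what this kind of exchange does, so the expectation rests on the value of compound 1 alone. Compound 3 is expected to need a noticeably larger amount than compound 1, an estimated step of a 6.6-fold higher number from compound 1 to compound 3 (0.82 log units; beyond the scatter). For compound 3 the expected value in this assay is 1500 nM, with a range from 400 nM to 6000 nM.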

Compound 3, half-maximal effective concentration: 3410 nM
The estimate for compound 3 lay 2.3-fold (0.36 log units) below the measured number; low and high end bracket the measured number.
By their numbers in this assay, from the lowest: compound 2; then compound 1; then compound 3.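

On the carbonyl carbon of the shared core, 3-(trifluoromethyl)phenyl cannot be exchanged for cyclopentyl without a large loss in this assay: the change brings a 15-fold higher number from compound 1 to compound 3 (1.17 log units; beyond the scatter). Going by these compounds alone, this is the first single-place reading of this position, as compound 1 and compound 2 differ in more than one place and could not isolate the effect of this group. The exchange alters ring size, aromatic character and fluorine content all at once, and no measurement here explains the loss.

Which of these differences matters remains open: an unsubstituted phenyl ring or a cyclohexyl ring on the same carbonyl carbon would help to separate them. Also open, as far as these compounds go, is how a straight alkyl chain or an amine would fare at this place.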